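The compounds below may be only part of what the source reports. "The series", "measured", "known", "first", "only" and "open" are said of these compounds alone.

Compound 1 `Oc1cccc(-c2cc(-c3ccc(F)cc3)cc(-c3ccccc3O)n2)c1` and compound 2 `Oc1ccc(-c2cc(-c3ccc(F)cc3)cc(-c3ccccc3O)n2)cc1` share one core; compound 3 `Oc1ccc(-c2cc(-c3ccccc3OC(F)(F)F)cc(-c3cccc(O)c3)n2)cc1` and compound 4 `Oc1ccc(-c2cc(-c3ccccc3OC(F)(F)F)cc(-c3ccc(O)cc3)n2)cc1` share another, and the difference between the two cores is not broken down here. In a functional assay on T47D cells (Homo sapiens) for inhibition (on this read-out higher numbers stand for weaker inhibition and lower numbers for stronger inhibition), compound 1 gives only a limit, > 50000 nM. In this assay compound 2 likewise gives only a limit, > 50000 nM. The change 4-hydroxyphenyl in place of 3-hydroxyphenyl on an aromatic carbon thus yields a step that the two limits leave unreadable from compound 1 to compound 2, both values resting at the limit of > 50000 nM in this assay, at which 2 of the 3 values shown sit. In this assay compound 3 gives 7300 nM. Compound 4 carries the same kind of change, (4-hydroxyphenyl in place of 3-hydroxyphenyl on an aromatic carbon), though the surroundings differ: meta to a 4-hydroxyphenyl group and meta to a large group, where in compound 1 the place is meta to a 2-hydroxyphenyl group and meta to a 4-fluorophenyl group. With the earlier step unreadable, no direction is supported, and a small step is expected: a 1.4-fold higher number from compound 3 to compound 4 (0.14 log units; within the scatter). Compound 4 is therefore estimated at 10000 nM, between 2500 nM and 40000 nM.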

Compound 4, half-maximal inhibitory concentration: 9840 nM
For compound 4 the middle estimate is 1.0-fold (0.01 log units) above the measured one, within the range that was stated.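

In this assay, 4-hydroxyphenyl in place of 3-hydroxyphenyl on the core of compound 3 gives a 1.3-fold higher number from compound 3 to compound 4 (0.13 log units; within the scatter), so on this core the two groups cannot be told apart. On the core of compound 1 the same change cannot be read, because both values there are limits: the limit of > 50000 nM in this assay, at which 2 of the 4 values shown sit.

The change therefore has only one readable instance, and whether its effect carries from one core to the other is not shown.

The compounds shown carry only hydroxyphenyl groups at this place, so how an aminophenyl group there would read in this assay stays open. From the compounds shown here alone, what the difference between the two cores contributes also stays open.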